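Adding a Chloro Group to a Dihydrofolate Reductase Inhibitor

A few compounds are considered here, and "the series" means these few. Any claim that something is new, unique, unknown or untested is made for them only; others in the source may bear on it.

Compound 1 `NC1=NC2(CCOCC2)N(OCCCOc2ccccc2)C(N)=N1` is one of a pair of related compounds tested in an assay on isolated protein for inhibition of Dihydrofolate reductase (Homo sapiens), read by spectrophotometry, using NADPH, with stated times of 5 s and 6 min, tested at 50 uM; a lower number here means a weaker effect, a higher number a stronger effect of the compound at the concentration tested. For compound 1 the result in this assay is "not determined" (no result reported), so no single number anchors it. Among the measured compounds shown here, a close relative, compound 2 `CC(C)(C)c1ccc(OCCCON2C(N)=NC(N)=NC23CCSCC3)cc1`, is the only compound here with a number: in this assay compound 2 gives 86.6%, a strong effect at the concentration used.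

Compound 3 `NC1=NC2(CCOCC2)N(OCCCOc2ccccc2Cl)C(N)=N1` differs from compound 1 in one place: chloro in place of hydrogen on an aromatic carbon. For the measured compounds named here, no measured pair of this kind is available, so the size of the step in this assay is unknown. A change this small is expected to move the result only modestly, if at all, in either direction beyond the usual scatter.

The expectation for compound 3 rests mainly on compound 2, which gives 86.6% with the same core arrangement. Compound 3 is therefore expected to give about 78% in this assay, with a likely range from 55% to 95%.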

Compound 3, a percentage reported as inhibition, at one concentration (the size of the read-out at that concentration, not a potency): 88.2%
Compound 3: middle estimate off by 10.2 percentage points, on the low side, and the stated range covers the measured number.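

No step can be read from compound 1 to compound 3, since compound 1 has no number in this assay to set against the result of compound 3 (88.2%). No measured evidence bears on this result. As far as these compounds go, what the chloro group itself contributes in this assay stays open.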